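An acetyl for a methyl on the side-chain oxygen

A few compounds are considered here, and "the series" means these few. Any claim that something is new, unique, unknown or untested is made for them only; others in the source may bear on it.

Compound 2, `CCOc1c(-c2occ(C)c2COC)ccc2c(CC)cccc12`, was tested in a functional assay on KB cells (Homo sapiens) for cytotoxicity, read by MTT assay, with a stated time of 72 h; on this read-out lower numbers stand for an effect already at smaller amounts and higher numbers for an effect only at larger amounts of compound. In this assay compound 2 gives only a limit of the assay, > 10 ug/mL, and no number. Compound 1, `CCc1cccc2c(OC)c(-c3occ(C)c3COC(C)=O)ccc12`, likewise gives only a limit in this assay, > 10 ug/mL. For the measured compounds named here, compound 2 thus stands where every value so far stands, at the limit of > 10 ug/mL in this assay, at which 2 of the 2 values shown sit, and nothing places it above or below compound 1.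

Compound 3, `CCOc1c(-c2occ(C)c2COC(C)=O)ccc2c(CC)cccc12`, differs from compound 2 by acetyl in place of methyl on an oxygen on a saturated carbon; cut one bond further out, methoxymethyl becomes acetoxymethyl. Going by the values given here, no step between two measured compounds is available, since compound 1 and compound 2 differ in two places at once. Compound 1 already carries the acetoxymethyl group and gives only a limit in this assay, > 10 ug/mL. On that basis the step from compound 2 to compound 3 is expected to be none beyond the scatter, a step that the limit leaves unreadable from compound 2 to compound 3, and most likely a limit again. Compound 3 is expected to give 20 ug/mL in this assay, in the range 8 ug/mL to 50 ug/mL.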

Compound 3, concentration for half-maximal effect: > 10 ug/mL
Compound 3: a limit, no number (the forecaster's own chance of this, stated with the estimate: 80%); the middle value does not contradict the limit.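

In this assay compound 3 gives only a limit of the assay, so no step can be read from compound 2 or compound 1 to compound 3, and the three stand together: the limit of > 10 ug/mL in this assay, at which 3 of the 3 values shown sit. The compounds shown leave open whether acetyl in place of methyl on the side-chain oxygen changes the cytotoxicity at all, as none of them gives a number.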